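This account rests on a few compounds, and the source may have more. Where it says the series, first, only, none or still open, it means among the compounds named here.

Working notes on the series. Three measured analogues share one core and differ only in the group attached to the carbonyl carbon of the amide. Compound 1 `Cc1cc(NC(=O)C2CCOCC2)nn1Cc1cc(Cl)ccc1OCc1ccccc1` gives 9.1 mL.min-1.g-1 in an in vitro ADME assay on microsomes from liver (Rattus norvegicus) for metabolic stability; on this read-out lower numbers stand for slow clearance and higher numbers for fast clearance. Compound 2 `Cc1cc(NC(=O)c2ccccc2)nn1Cc1cc(Cl)ccc1OCc1ccccc1` gives 7.3 mL.min-1.g-1 in this assay, and a 1.2-fold lower number from compound 1 to compound 2 (0.10 log units; within the scatter). Compound 3 `Cc1cc(NC(=O)OC(C)(C)C)nn1Cc1cc(Cl)ccc1OCc1ccccc1` gives 2.2 mL.min-1.g-1 in this assay, the lowest of the three numbers: a 4.1-fold lower number from compound 1 to compound 3 (0.62 log units; beyond the scatter) and a 3.3-fold lower number from compound 2 to compound 3 (0.52 log units; beyond the scatter).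

Compound 4 `Cc1cc(NC(=O)OCc2ccccn2)nn1Cc1cc(Cl)ccc1OCc1ccccc1` is not yet measured. The change from compound 3 is (pyridin-2-yl)methyl in place of tert-butyl on an oxygen next to a carbonyl group. Among the measured compounds shown here, no measured step alters this oxygen-bound group, so none bears on it directly; the two steps that come closest are those into compound 3, both modest falls in the number, and both came with tert-butoxy entering. Since tert-butyl now leaves compound 3, the expectation is a partial return toward the numbers of compound 1 and compound 2, expected as a 2.7-fold higher number from compound 3 to compound 4 (0.44 log units; beyond the scatter), but with wide uncertainty because a 3.3-fold lower number from compound 2 to compound 3 (0.52 log units; beyond the scatter) and a 4.1-fold lower number from compound 1 to compound 3 (0.62 log units; beyond the scatter) describe a different substituent entering. Compound 4 is therefore estimated at 6 mL.min-1.g-1 in this assay, with a range from 2.5 mL.min-1.g-1 to 14 mL.min-1.g-1.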

Compound 4, intrinsic clearance in microsomes: 8.4 mL.min-1.g-1
Beside the measured number, compound 4's estimate is 1.4-fold (0.15 log units) below it; the measured number falls inside the stated range.
By their numbers in this assay, from the lowest: compound 3; then compounds 2, 4 and 1 (each within the scatter of the next).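

In this assay the group on the oxygen next to a carbonyl group is not a silent position: (pyridin-2-yl)methyl in place of tert-butyl gives a 3.8-fold higher number from compound 3 to compound 4 (0.58 log units; beyond the scatter) and so removes the low number of compound 3 while the oxygen on the carbonyl carbon stays. The low number therefore goes with tert-butoxy in this set, not with every oxygen-linked group on that carbonyl carbon, and (pyridin-2-yl)methoxy cannot be told apart from phenyl, with a 1.2-fold higher number from compound 2 to compound 4 (0.06 log units; within the scatter) as the step, or from oxan-4-yl, with a 1.1-fold lower number from compound 1 to compound 4 (0.03 log units; within the scatter) as the step. No measurement in hand accounts for the step away from tert-butyl.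

With only two groups on this oxygen, the compounds shown do not separate the loss of tert-butyl from the entry of the pyridine ring, and a benzyl, isopropyl or ethyl group there would tell whether the ring nitrogen or the branching of the chain goes with the change. As far as these compounds go, whether any other replacement on this oxygen, such as a cyclobutyl group or a longer chain carrying an amine, would hold the number near that of compound 3 also stays open.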